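Replacing the Diethylcarbamoyl Group of Compound 2

A few compounds are considered here, and "the series" means these few. Any claim that something is new, unique, unknown or untested is made for them only; others in the source may bear on it.

In a functional assay on U-87MG ATCC cells for cytotoxicity against U-87 MG (Homo sapiens), read by colorimetric assay and MTT assay (on this read-out higher numbers stand for weaker inhibition and lower numbers for stronger inhibition), compound 1 (`COc1cc(OC)c2cc(-c3ccc(OCc4ccccc4)cc3)c(O)nc2c1`) gives 10000 nM, and compound 2 (`CCN(CC)C(=O)Cn1c(=O)c(-c2ccc(OC)cc2)cc2c(OC)cc(OC)cc21`) gives 10000 nM, so compound 2 stands level with compound 1. Compound 3 (`COC(=O)CCn1c(=O)c(-c2ccc(OC)cc2)cc2c(OC)cc(OC)cc21`) carries (methoxycarbonyl)methyl in place of diethylcarbamoyl on a saturated chain carbon bound to an aromatic nitrogen. Among the compounds with values here, no step between measured compounds is available to guide the expectation. The expected change, no change at the digits printed from compound 2 to compound 3 (within the scatter), stays within the scatter, in neither direction. For compound 3 the estimated value is 10000 nM, with an expected range of 5000 nM to 20000 nM.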

Compound 3, half-maximal inhibitory concentration: 10000 nM
Estimate against measurement, compound 3: no gap at the digits printed; the range from low to high includes it.
By their numbers in this assay, from the lowest: compounds 1, 2 and 3 (each within the scatter of the next).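

Read in this assay, the change gives no change at the digits printed from compound 2 to compound 3 (within the scatter), the first step available at this position. On this core, then, (methoxycarbonyl)methyl and diethylcarbamoyl cannot be told apart on a saturated chain carbon bound to an aromatic nitrogen. No measurement shown offers an explanation for this result.

From the compounds shown here alone, whether a carboxylic acid or a primary amine at the end of this chain would shift the value of compound 3 from 10000 nM remains open. So does the effect of a longer chain.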